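The source may hold more compounds than are shown below. What is called first, only, known or untested is meant among the compounds shown, and "the series" means these compounds.

Measured so far:
compound 1 `COc1ccc(CN(C)CCCn2c(=O)oc3ccccc32)cc1` — 83 nM
compound 2 `Cc1cccc(CN(C)CCCn2c(=O)oc3ccccc32)c1` — 1840 nM

Going by the values given here, in an assay on membranes from liver for displacement of a labelled ligand from Sigma non-opioid intracellular receptor 1 (Rattus norvegicus), read by scintillation counting (a higher number here means a weaker inhibitor, a lower number a stronger inhibitor), compound 2 gives the higher of the two numbers; the one measured step, a 22-fold higher number from compound 1 to compound 2 (1.35 log units; beyond the scatter), is the only comparison available. Compound 3 `Cc1ccc(CN(C)CCCn2c(=O)oc3ccccc32)c(C)c1` differs from compound 2 by 2,4-dimethylphenyl in place of 3-methylphenyl on a saturated chain carbon bound to an amine nitrogen. Among the compounds with values here, no measured step swaps one methyl-bearing phenyl for another, so the step from compound 1 to compound 2 bears on this only distantly; it shows the aromatic substituent matters, not which direction a second methyl moves the number. For compound 3 no step beyond the scatter is expected, a 1.2-fold lower number from compound 2 to compound 3 (0.09 log units; within the scatter). The estimate for compound 3 in this assay is 1500 nM, with a range from 400 nM to 6000 nM.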

Compound 3, inhibition constant: 1830 nM
Beside the measured number, compound 3's estimate is 1.2-fold (0.09 log units) below it, within the range that was stated.
By their numbers in this assay, from the lowest: compound 1; then compounds 3 and 2 (each within the scatter of the next).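

In this assay, a second methyl on the phenyl ring, 2,4-dimethylphenyl in place of 3-methylphenyl, leaves the number where it was (a 1.0-fold lower number from compound 2 to compound 3 (0.00 log units; within the scatter)). With 4-methoxyphenyl replaced by 2,4-dimethylphenyl, the step is large as well (a 22-fold higher number from compound 1 to compound 3 (1.34 log units; beyond the scatter)), so compound 1 stands apart from both methyl-bearing compounds. Nothing at hand explains these numbers.

Open, going by these compounds, is whether 4-ethoxyphenyl, 4-hydroxyphenyl or 3-methoxyphenyl at this place would keep the number of compound 1. Also open, on these data alone, is whether 4-methylphenyl would fall with compound 2 and compound 3.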